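Benzyl ring swap on the most potent pyrazole acid

The compounds below may be only part of what the source reports. "The series", "measured", "known", "first", "only" and "open" are said of these compounds alone.

Compound 3 `Cc1cc(C(=O)O)nn1Cc1cc(Br)ccc1OCc1ccc(Cl)cc1Cl` gives 0.49 nM in a functional assay on CHO-K1 cells for antagonist activity at prostaglandin E2 receptor EP1 subtype (Homo sapiens), read by FLIPR (on this read-out higher numbers stand for weaker inhibition and lower numbers for stronger inhibition), the lowest number among the three measured compounds. Compound 1 `O=C(O)c1nn(Cc2cc(Br)ccc2OCc2ccccc2)cc1F` gives 692 nM and compound 2 `Cc1cn(Cc2cc(Br)ccc2OCc2ccccc2)nc1C(=O)O` gives 1350 nM; the gap from compound 3 to each of them is beyond the scatter. Compound 4 `Cc1cc(C(=O)O)nn1Cc1cc(Br)ccc1OCc1c(F)cccc1F` differs from compound 3 by 2,6-difluorophenyl in place of 2,4-dichlorophenyl on a saturated chain carbon bound to an oxygen on an aromatic ring. For the measured compounds named here, no measured step touches this position: the only single-point step, a 2.0-fold higher number from compound 1 to compound 2 (0.29 log units; within the scatter), concerns the core and is within the scatter, and compounds 1 and 2 differ from compound 3 at the core as well as the benzyl ring, so their gap cannot be assigned. A step of an 8.2-fold higher number from compound 3 to compound 4 (0.91 log units; beyond the scatter) toward a higher number is expected, with wide uncertainty. Compound 4 is estimated at 4 nM, between 0.6 nM and 30 nM.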

Compound 4, inhibition constant: 105 nM
Compound 4: middle estimate off by 26-fold (1.42 log units), on the low side, outside the stated range (above it).
By their numbers in this assay, from the lowest: compound 3; then compound 4; then compounds 1 and 2 (each within the scatter of the next).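

In this assay, for the compounds shown here, the step of a 210-fold higher number from compound 3 to compound 4 (2.33 log units; beyond the scatter) is the first read at this position, and it shows that the number here is highly sensitive to the choice between two dihalogenated phenyl groups with the same count of heavy atoms. Both the halogen and its placement on the ring change in this single step. Nothing measured here explains the size of the step.

Which of the two changes carries the step remains open, as does how a phenyl ring bearing trifluoromethyl or methoxy would read at this place.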